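The compounds below may be only part of what the source reports. "The series", "measured", "known", "first", "only" and "open" are said of these compounds alone.

Measured in an in vitro ADME assay on microsomes from liver (Homo sapiens) for pharmacokinetics; a lower number here means slower removal, a higher number faster removal of the compound:
- compound 1 `O=C(N[C@@H](CCN1C[C@@H]2CN(C(=O)c3ccccn3)C[C@@H]2C1)c1cccc(F)c1)C1CCCC1`: 512 mL.min-1.g-1
- compound 2 `O=C(N[C@@H](CCN1C[C@@H]2CN(C(=O)c3ccccn3)C[C@@H]2C1)c1cccc(F)c1)C1CCOC1`: 55 mL.min-1.g-1
- compound 3 `O=C(N[C@@H](CCN1C[C@@H]2CN(C(=O)c3cncnc3)C[C@@H]2C1)c1cccc(F)c1)C1CCCC1`: 332 mL.min-1.g-1

Compound 2 has the lowest number of the three, at 55 mL.min-1.g-1, well under compound 3 and compound 1. Compound 4 `O=C(N[C@@H](CCN1C[C@@H]2CN(C(=O)c3ccc(C(F)(F)F)cn3)C[C@@H]2C1)c1cccc(F)c1)C1CCOC1` departs from it by one change, trifluoromethyl in place of hydrogen on an aromatic carbon, turning pyridin-2-yl into 5-(trifluoromethyl)pyridin-2-yl.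

Among the measured compounds shown here, two measured steps bear on this only indirectly. The step of a 1.5-fold lower number from compound 1 to compound 3 (0.19 log units; within the scatter) alters the aromatic ring on the same carbonyl, pyrimidin-5-yl in place of pyridin-2-yl, and stays within the scatter. The larger step of a 9.3-fold lower number from compound 1 to compound 2 (0.97 log units; beyond the scatter) comes from oxolan-3-yl replacing cyclopentyl elsewhere in the molecule, and it shows how far the number can move in this set. For the measured compounds named here, no measured step adds a trifluoromethyl, so the direction is a judgement. Compound 2 at 55 mL.min-1.g-1 already sits lowest, so a modest rise seems likelier than a further fall.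

In this assay the expected step is a 1.8-fold higher number from compound 2 to compound 4 (0.26 log units; within the scatter), smaller than the oxolan-3-yl step. For compound 4 the estimated value is 100 mL.min-1.g-1, with an expected range of 45 mL.min-1.g-1 to 240 mL.min-1.g-1.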

Compound 4, intrinsic clearance in microsomes: 343 mL.min-1.g-1
Compound 4: the middle estimate sits 3.4-fold (0.54 log units) below what was measured, outside the stated range (above it).
By their numbers in this assay, from the lowest: compound 2; then compounds 3, 4 and 1 (each within the scatter of the next).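

In this assay, trifluoromethyl in place of hydrogen on the pyridin-2-yl ring, para to a large group and two atoms from the ring nitrogen, gives a 6.2-fold higher number from compound 2 to compound 4 (0.79 log units; beyond the scatter). Among the compounds shown here, until now, the only step beyond the scatter was the oxolan-3-yl change, a 9.3-fold lower number from compound 1 to compound 2 (0.97 log units; beyond the scatter), while the one step altering the aromatic group stayed within it, so this result shows that a change on that ring can also move the number beyond the scatter. Nothing available explains this rise.

On these data alone, it remains open whether a smaller group at this position, such as a fluorine, a methyl or a nitrile, would raise the number as well. It is also unknown whether trifluoromethyl would give a similar step with cyclopentyl in place of oxolan-3-yl.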